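Acetyl in Place of Arylsulfonyl: Expected Loss of Potency

The source may hold more compounds than are shown below. What is called first, only, known or untested is meant among the compounds shown, and "the series" means these compounds.

Compound 1 `COc1ccc(S(=O)(=O)N2CCc3cccc(NCc4ccccc4)c32)cc1` gives only a limit, > 10000 nM, in a functional assay on MKN-45 cells (Homo sapiens) for cytotoxicity; on this read-out higher numbers stand for weaker inhibition and lower numbers for stronger inhibition.
Compound 2 `COc1ccc(S(=O)(=O)N2CCc3cccc(NS(=O)(=O)c4ccc(F)cc4)c32)cc1` gives 890 nM in this assay.

Compound 2 thus holds the only number shown; the other value is a limit. Compound 3 `COc1ccc(S(=O)(=O)N2CCc3cccc(NC(C)=O)c32)cc1` differs from compound 2 by acetyl in place of (4-fluorophenyl)sulfonyl on a nitrogen on an aromatic ring. For the measured compounds named here, the one measured step at this nitrogen, an at least 11-fold lower number from compound 1 to compound 2 (1.05 log units; beyond the scatter), rests on a limit (the limit of > 10000 nM in this assay, at which 1 of the 2 values shown sits), so its true size is at least that large. It shows that the group on this nitrogen moves the read-out strongly, and removing the (4-fluorophenyl)sulfonyl for the far smaller acetyl is expected to weaken compound 3, giving an estimated step of a 5.6-fold higher number from compound 2 to compound 3 (0.75 log units; beyond the scatter). Compound 3 is estimated at 5000 nM, in the range 1500 nM to 20000 nM.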

Compound 3, half-maximal inhibitory concentration: 61 nM
Compound 3: middle estimate off by 82-fold (1.91 log units), on the high side; the whole stated range lies above it.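

Acetyl in place of (4-fluorophenyl)sulfonyl on this nitrogen gives a 15-fold lower number from compound 2 to compound 3 (1.16 log units; beyond the scatter) in this assay, so an aromatic ring in this group is not needed for a low number. Acetyl also far outdoes benzyl here, with an at least 160-fold lower number from compound 1 to compound 3 (2.21 log units; beyond the scatter) as the step, and its true size may be larger, since compound 1 gives only a limit: the limit of > 10000 nM in this assay, at which 1 of the 3 values shown sits.

The compounds shown leave open whether the free amine, a longer chain such as propanoyl, or a methanesulfonyl group on this nitrogen would hold the number this low. They also leave open whether the carbonyl of the acetyl matters.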